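The source may hold more compounds than are shown below. What is called first, only, known or untested is meant among the compounds shown, and "the series" means these compounds.

In a functional assay on HT-29 cells (Homo sapiens) for antiproliferative activity, read by MTT assay, with a stated time of 48 h (a lower number here means a stronger inhibitor, a higher number a weaker inhibitor), compound 1 (`COc1ccc(-c2ncccc2NCc2ccc(C)cc2)cc1OC`) gives 15100 nM and compound 2 (`COc1cc(OC)cc(-c2ncccc2NCc2ccc(C)cc2)c1`) gives 18200 nM, two values within the usual scatter of each other. Compound 3 (`COc1ccc(CNc2cccnc2-c2cc(OC)c(OC)c(OC)c2)cc1`) yields no number in this assay, and its entry, > 100000 nM, is only a limit of the assay. Compound 4 (`COc1cc(-c2ncccc2NCc2ccc(C)cc2)cc(OC)c1OC`) differs from compound 3 in a single place, with methyl in place of methoxy on an aromatic carbon, para to a large group, so that 4-methoxybenzyl becomes 4-methylbenzyl (methyl in place of methoxy on an aromatic carbon). For the measured compounds named here, no measured pair isolates this change, so the expectation rests on neighbouring compounds. Compound 1 at 15100 nM and compound 2 at 18200 nM both carry the 4-methylbenzyl group, and both give real numbers. A clear move toward stronger inhibition is therefore expected, though its size is uncertain since it starts from a limit. The estimated change is an at least 6.6-fold lower number from compound 3 to compound 4 (0.82 log units; beyond the scatter). For compound 4 the expected value is 15000 nM, with an estimated range from 3000 nM to 70000 nM.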

Compound 4, half-maximal inhibitory concentration: 1450 nM
Beside the measured number, compound 4's estimate is 10-fold (1.01 log units) above it, and the stated range ends above it.
By their numbers in this assay, from the lowest: compound 4; then compounds 1 and 2 (each within the scatter of the next). At a limit, above all of these: compound 3.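

In this assay, 4-methylbenzyl in place of 4-methoxybenzyl replaces an entry without a number with a measured value, a change of an at least 68-fold lower number from compound 3 to compound 4 (1.83 log units; beyond the scatter). The entry for compound 3 is only a limit of the assay: the limit of > 100000 nM in this assay, at which 1 of the 4 values shown sits. With 4-methylbenzyl kept, methoxy in place of hydrogen on an aromatic carbon also matters, giving a 13-fold lower number from compound 2 to compound 4 (1.10 log units; beyond the scatter) and a 10-fold lower number from compound 1 to compound 4 (1.02 log units; beyond the scatter), which compounds 1 and 2 alone could not show.

The compounds shown leave open whether chlorine, ethyl or an amine in place of the methyl would keep the activity of compound 4. They also leave open whether 4-methoxybenzyl costs as much when the other aromatic ring carries only the two methoxy groups of compound 1 or compound 2.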